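A few compounds are considered here, and "the series" means these few. Any claim that something is new, unique, unknown or untested is made for them only; others in the source may bear on it.

Compound 1 (`Cc1ccc(-c2c(C)nc(NC(=O)NC3CCCCC3)c(C)c2C(OC(C)(C)C)C(=O)O)cc1C`) was examined in an ADME assay on MT4 cells (Homo sapiens) for cytotoxicity, read by MTT assay (on this read-out higher numbers stand for lower toxicity in this test and lower numbers for higher toxicity in this test), where compound 1 gives 7900 nM. Of the two compounds measured in this assay, compound 1 has the lower number; the other, compound 2 (`Cc1ccc(-c2c(C)nc(NS(=O)(=O)c3cccc4ccccc34)c(C)c2C(OC(C)(C)C)C(=O)O)cc1C`), gives in this assay 16000 nM, and the gap between these two values is wider than the usual scatter of repeated measurements. Compound 3 (`Cc1ccc(-c2c(C)nc(NC(=O)NC3CCCCCC3)c(C)c2C(OC(C)(C)C)C(=O)O)cc1C`) has not yet been measured. It differs from compound 1 in a single place: cycloheptyl in place of cyclohexyl on an amide-type nitrogen. For the measured compounds named here, no measured pair shows what such a change does in this assay, so the expectation for compound 3 rests on compound 1 alone. A change of this kind, a ring of carbon only growing by one member on the amide-type nitrogen, is expected to move the number by a step that stays close to the scatter, with a slight lean towards a lower number, so that the step of a 1.2-fold lower number from compound 1 to compound 3 (0.08 log units; within the scatter) is what is expected. Compound 3 is therefore estimated to give 6500 nM in this assay, with a range from 2500 nM to 16000 nM.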

Compound 3, half-maximal cytotoxic concentration: 7700 nM
The estimate for compound 3 lay 1.2-fold (0.07 log units) below the measured number; low and high end bracket the measured number.
By their numbers in this assay, from the lowest: compounds 3 and 1 (each within the scatter of the next); then compound 2.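

In this assay the change reads as a 1.0-fold lower number from compound 1 to compound 3 (0.01 log units; within the scatter) and so gives no measurable shift: cycloheptyl in place of cyclohexyl on an amide-type nitrogen leaves the number where it stood. For the compounds shown here, this is the first step that can be read at this position, and it shows that a ring of carbon only can grow by one member here without any change in this test that rises above the scatter. No evidence is available that would explain why the two rings read alike.

What the compounds shown leave open is whether this insensitivity extends beyond these two rings, for instance to an open chain such as n-hexyl, to a phenyl ring, or to a cyclohexyl ring carrying an amine or a hydroxyl group. Going by these compounds, it also remains open whether the same exchange would read alike on other versions of the shared core, since this single pair speaks only for the core of compound 1.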